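Furan to hydroxymethoxyphenyl swap on the cyclohexyl member

The source may hold more compounds than are shown below. What is called first, only, known or untested is meant among the compounds shown, and "the series" means these compounds.

Compound 3 `c1coc(CNCCCNc2ccnc3cc(C4CCCCC4)ccc23)c1` gives 4760 nM in an ADME assay on HepG2 cells (Homo sapiens) for cytotoxicity, read by luminescence, CellTiter-Glo and ATP content, with a stated time of 72 h (on this read-out higher numbers stand for an effect only at larger amounts of compound and lower numbers for an effect already at smaller amounts), the highest of the three numbers: compound 1 `COc1cccc(CNCCCNc2ccnc3cc(-c4ccccc4)ccc23)c1O` with 3210 nM sits within the scatter of it, while compound 2 `COc1cccc(CNCCCNc2ccnc3cc(CC4CCCCC4)ccc23)c1O` with 970 nM lies beyond. Within the data shown here, the only counted step, a 3.3-fold lower number from compound 1 to compound 2 (0.52 log units; beyond the scatter), concerns the group on the aromatic carbon of the shared core, not the amine end. Compound 4 `COc1cccc(CNCCCNc2ccnc3cc(C4CCCCC4)ccc23)c1O` carries 2-hydroxy-3-methoxyphenyl in place of furan-2-yl on a saturated chain carbon bound to an amine nitrogen. Among the measured compounds shown here, no measured step covers this change, so its direction rests only on compounds 1 and 2 carrying the same entering group. A modest downward step is expected, a 2.4-fold lower number from compound 3 to compound 4 (0.38 log units; beyond the scatter), because compound 2 with 970 nM already shares the cyclohexyl-type substituent. Compound 4 is estimated at 2000 nM, between 700 nM and 5500 nM.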

Compound 4, half-maximal effective concentration: 1080 nM
Compound 4: the middle estimate sits 1.9-fold (0.27 log units) above what was measured; measured number inside the range.
By their numbers in this assay, from the lowest: compounds 2 and 4 (each within the scatter of the next); then compounds 1 and 3 (each within the scatter of the next).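

In this assay the amine end now has a reading of its own, a 4.4-fold lower number from compound 3 to compound 4 (0.64 log units; beyond the scatter) for 2-hydroxy-3-methoxyphenyl in place of furan-2-yl. With that group kept, cyclohexyl in place of phenyl on the aromatic carbon gives a 3.0-fold lower number from compound 1 to compound 4 (0.47 log units; beyond the scatter) while cyclohexyl in place of cyclohexylmethyl gives a 1.1-fold higher number from compound 2 to compound 4 (0.05 log units; within the scatter) and so does not separate the two groups. No measurement at hand explains these steps.

Open, from the compounds shown here alone, is how much of the amine-end step belongs to the hydroxy and how much to the methoxy, which a plain benzyl at that place would separate. Also open, going by these compounds, is whether the step holds with phenyl on the shared core.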